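The source may hold more compounds than are shown below. What is called first, only, known or untested is meant among the compounds shown, and "the series" means these compounds.

Within the data shown here, compound 1 `CN1CCN(CCCN(c2nc3cc(F)c(F)cc3[nH]2)[C@@H]2CC[C@]3(c4cccc(C#N)c4)C[C@@H]3C2)CC1` is one of two compounds measured in an assay on isolated protein for binding affinity to melanin-concentrating hormone receptor 1 (Homo sapiens) (a lower number here means a stronger inhibitor, a higher number a weaker inhibitor), where compound 1 gives 8.4 nM. Its companion, compound 2 `CN1CCN(CCCN(c2nc3cc(F)c(Cl)cc3[nH]2)[C@@H]2CC[C@]3(c4cccc(C#N)c4)C[C@@H]3C2)CC1`, differs from it only in one halogen on the shared core and gives 6.2 nM in this assay. The step of a 1.4-fold lower number from compound 1 to compound 2 (0.13 log units; within the scatter) is too small to separate the two, so compound 1 sits alongside compound 2 within the usual scatter, with no other number to set it against.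

Compound 3 `CN1CCN(CCCN(c2nc3cc(F)c(F)cc3[nH]2)[C@@H]2CC[C@]3(c4cccc(CN5CCCCC5)c4)C[C@@H]3C2)CC1` keeps the whole of compound 1 except at one point on the aromatic ring that hangs from the bicyclic part: (piperidin-1-yl)methyl in place of cyano on an aromatic carbon. Among the measured compounds shown here, the only step measured so far concerns a halogen on a different ring and says nothing about this exchange, so no measured step bears on it. There is therefore no basis for predicting a direction, and the expectation for this assay is a step of a 1.8-fold higher number from compound 1 to compound 3 (0.25 log units; within the scatter), a change that may well stay within the scatter. On that basis compound 3 is estimated to give 15 nM in this assay, with a range from 3 nM to 80 nM.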

Compound 3, inhibition constant: 405 nM
For compound 3 the middle estimate is 27-fold (1.43 log units) below the measured one; measured number above the stated range.
By their numbers in this assay, from the lowest: compounds 2 and 1 (each within the scatter of the next); then compound 3.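

Among these compounds, at this carbon of the six-membered aromatic ring, the group matters a great deal in this assay: the exchange gives a 48-fold higher number from compound 1 to compound 3 (1.68 log units; beyond the scatter), whereas the only earlier step, a 1.4-fold lower number from compound 1 to compound 2 (0.13 log units; within the scatter), changed a halogen elsewhere on the molecule and stayed within the scatter. The change in hydrogen-bonding counts offers no contrast, since cyano and (piperidin-1-yl)methyl each have 0 hydrogen-bond donors and 1 hydrogen-bond acceptor and neither carries a net charge; what differs in the counts is the step from 2 heavy atoms to 7, the added six-membered non-aromatic ring and the lost triple bond. No measurement at hand accounts for this large loss of affinity.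

With a single exchange, these differences cannot be told apart: a methyl group, an aminomethyl group or a morpholin-4-ylmethyl group at the same carbon would help to show whether the ring, the amine nitrogen or simply the loss of the nitrile matters most. On these data alone, it also remains open whether the (piperidin-1-yl)methyl group has the same effect on the core of compound 2, which carries chloro in place of one fluoro.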